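Swapping the saturated ring tail for a methylbenzyl

A few compounds are considered here, and "the series" means these few. Any claim that something is new, unique, unknown or untested is made for them only; others in the source may bear on it.

Of the compounds shown here, three sharing one core have been measured in an assay on isolated protein for binding affinity to Gonadotropin-releasing hormone receptor (Rattus norvegicus); on this read-out lower numbers stand for stronger inhibition and higher numbers for weaker inhibition. Compound 1 `Cc1cc2c(cc1Cc1ccc(C(=O)NCC3CCCCC3)o1)C(C)(C)CCC2(C)C` gives 1550 nM. Compound 2 `Cc1cc2c(cc1Cc1ccc(C(=O)NC[C@H]3CC[C@H](C(N)=O)CC3)o1)C(C)(C)CCC2(C)C` gives 270 nM. Compound 3 `CCOC(=O)[C@H]1CC[C@H](CNC(=O)c2ccc(Cc3cc4c(cc3C)C(C)(C)CCC4(C)C)o2)CC1` gives 2730 nM, the highest number of the three; the gap to compound 1 is within the scatter, while the gap to compound 2 is not.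

The steps among them read a 5.7-fold lower number from compound 1 to compound 2 (0.76 log units; beyond the scatter), a 1.8-fold higher number from compound 1 to compound 3 (0.25 log units; within the scatter) and a 10-fold higher number from compound 2 to compound 3 (1.00 log units; beyond the scatter). Compound 4 `Cc1ccc(CNC(=O)c2ccc(Cc3cc4c(cc3C)C(C)(C)CCC4(C)C)o2)cc1` arises from compound 3 by 4-methylphenyl in place of 4-(ethoxycarbonyl)cyclohexyl on a saturated chain carbon bound to an amide-type nitrogen. Within the data shown here, none of the measured steps changes the ring itself; the only step that bears on it is the one from compound 1 to compound 3, which shows that the ethoxycarbonyl group adds little, so losing it is not expected to cost much. For the swap of a saturated ring for an aromatic one there is no guide.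

Compound 4 is therefore expected to land near compound 1, the estimated step being a 1.5-fold lower number from compound 3 to compound 4 (0.18 log units; within the scatter). The estimate for compound 4 in this assay is 1800 nM, with a range from 500 nM to 6000 nM.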

Compound 4, inhibition constant: 60 nM
Beside the measured number, compound 4's estimate is 30-fold (1.48 log units) above it; measured number below the stated range.
By their numbers in this assay, from the lowest: compound 4; then compound 2; then compounds 1 and 3 (each within the scatter of the next).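

Replacing the saturated ring with an aromatic one has a far larger effect than the earlier changes made on the saturated ring: 4-methylphenyl in place of cyclohexyl gives a 26-fold lower number from compound 1 to compound 4 (1.41 log units; beyond the scatter). The same swap also lowers the number against both substituted rings, with a 46-fold lower number from compound 3 to compound 4 (1.66 log units; beyond the scatter) and a 4.5-fold lower number from compound 2 to compound 4 (0.65 log units; beyond the scatter), so compound 4 stands lowest of the four in this assay. Compound 2 had suggested that carbamoyl might be what a low number needs here, but the 4-methylphenyl group of compound 4 does better with no hydrogen-bond donors or acceptors.

From the compounds shown here alone, how a plain phenyl, a 4-aminophenyl or a 4-carboxyphenyl group would read at this position remains open, as does the methyl group's own contribution. Nothing shown here gives a reason for the aromatic ring's lower number.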